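A Methoxy Group Added to Compound 2

This account rests on a few compounds, and the source may have more. Where it says the series, first, only, none or still open, it means among the compounds named here.

Compound 1, `COc1cccc(-c2cc3[nH]nc(N)c3c(=O)[nH]2)c1`: 56%
Compound 2, `Cn1nc(N)c2c(=O)[nH]c(-c3ccccc3)cc21`: 37%

For the measured compounds named here, in an assay on isolated protein for inhibition of MAP kinase-activated protein kinase 2 (Homo sapiens), read by mobility shift assay, tested at 30 uM (a lower number here means less inhibition, a higher number more inhibition at the concentration tested (going by the name of the read-out)), compound 2 gives 37%, the lower of the two numbers measured so far. Compound 1 gives 56% in this assay, a number that lies above the value of compound 2 by more than the usual scatter; the two compounds differ in more than one place, so the gap cannot be traced to a single change.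

Compound 3, `COc1cccc(-c2cc3c(c(N)nn3C)c(=O)[nH]2)c1`, is not yet measured. It differs from compound 2 in one way: methoxy in place of hydrogen on an aromatic carbon. In compound 1 the same methoxy group is present, and compound 1 stands higher than compound 2, but that pair also differs elsewhere, so the comparison is only a hint. The step from compound 2 to compound 3 is expected to be a modest rise, a number 11 percentage points higher from compound 2 to compound 3 (beyond the scatter), perhaps only at the edge of the scatter. For compound 3 the expected inhibition in this assay is 48%, with a range from 30% to 68%.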

Compound 3, a percentage reported as inhibition, at one concentration (the size of the read-out at that concentration, not a potency): 47%
Beside the measured number, compound 3's estimate is 1 percentage points above it; the range from low to high includes it.
By their numbers in this assay, from the lowest: compounds 2, 3 and 1 (each within the scatter of the next, the first and the last beyond it).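

In this assay the swap of hydrogen for methoxy on an aromatic carbon, meta to a large group, comes to a number 10 percentage points higher from compound 2 to compound 3 (within the scatter) and so cannot be told apart from the usual scatter. Methyl in place of hydrogen on an aromatic nitrogen comes to a number 9 percentage points lower from compound 1 to compound 3 (within the scatter) and also stays inside that scatter. The gap between compound 1 and compound 2, which no single change could explain before, now divides into these two single steps, and neither one alone clears the scatter.

Nothing available bears on the reason for either step. From the compounds shown here alone, it remains open whether an amine or a carboxylic acid on that aromatic carbon, or a longer chain in place of the methyl on the nitrogen, would shift the inhibition beyond the scatter.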